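This account rests on a few compounds, and the source may have more. Where it says the series, first, only, none or still open, it means among the compounds named here.

Compound 1, `O[C@]1(c2ccccn2)CC[C@H](c2ccc(C(F)(F)F)cc2)C1`: 333 mL/min/kg
Compound 2, `OC(c1ccccn1)C1(c2ccccc2OC(F)(F)F)CCC1`: 1230 mL/min/kg

In an ADME assay on liver for metabolic stability, with Liver microsome (Homo sapiens) as the target, read by LC-MS, using microsomes, with a stated time of 5 h (a lower number here means slower removal, a higher number faster removal of the compound), compound 1 stands lowest of the two numbers. Compound 2 gives 1230 mL/min/kg, a number that lies beyond the usual scatter above compound 1. Compound 3, `O[C@@]1(c2ccccn2)CC[C@H](c2ccc(C(F)(F)F)cc2)C1`, keeps the same atoms and bonds as compound 1 and differs only in configuration as drawn: the two compounds have the same atoms and bonds and differ only in configuration as drawn: 1 of 2 stereo elements differ; a stereocentre at a saturated ring carbon is drawn R in compound 1 and S in compound 3. For the measured compounds named here, no measured pair here shows what such a change does, so compound 3 is expected to land close to compound 1, with a step of no change at the digits printed from compound 1 to compound 3 (within the scatter) that is expected to stay within the scatter. Compound 3 is thus estimated at 333 mL/min/kg, between 150 mL/min/kg and 740 mL/min/kg.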

Compound 3, clearance: 400 mL/min/kg
Compound 3: the middle estimate sits 1.2-fold (0.08 log units) below what was measured; measured number inside the range.
By their numbers in this assay, from the lowest: compounds 1 and 3 (each within the scatter of the next); then compound 2.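

In this assay, the change of configuration at this saturated ring carbon gives a 1.2-fold higher number from compound 1 to compound 3 (0.08 log units; within the scatter), so the drawn R and S forms cannot be told apart at this position. Compound 1 and compound 2 formed no single-change pair, whereas this step isolates one stereocentre: the fact that compounds 1 and 3 differ only in the configuration as drawn

Going by these compounds, the other stereo element is the same in compound 1 and compound 3, so the effect of changing it remains open. Also open, on these data alone, is how the number would respond if a nitrile or a carboxylic acid replaced the trifluoromethyl group.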